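The source may report more compounds than this note shows. Statements on the series, on what has been measured and on what is new or still open speak of the compounds shown alone.

Measured so far:
compound 1, `C[C@H]1O[C@@H]([C@@H]2CCCN2C)C[S@@+]1[O-]` — in an assay on CHO cells for binding affinity to muscarinic acetylcholine receptor M5 (Homo sapiens) (on this read-out lower numbers stand for stronger inhibition and higher numbers for weaker inhibition), compound 1 gives < 100000 nM, which is a limit of the assay and not a number.
compound 2, `C[C@@H]1O[C@H]([C@@H]2CCCN2C)C[S@@+]1[O-]` — in this assay compound 2 gives < 100000 nM, which is likewise a limit and not a number.

Going by the values given here, compound 2 therefore stands on a limit, and the only other value in the set, that of compound 1, is a limit as well. The step that the two limits leave unreadable from compound 1 to compound 2 cannot be sized because the limit of < 100000 nM in this assay, at which 2 of the 2 values shown sit, leaves both ends unreadable, even though the fact that compounds 1 and 2 differ only in the configuration as drawn makes it a pure change of configuration.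

Compound 3, `C[C@H]1O[C@@H]([C@H]2CCCN2C)C[S@+]1[O-]`, is the compound still to be measured. Compared with compound 2 the change is the two compounds have the same atoms and bonds and differ only in configuration as drawn: 4 of 4 stereo elements differ (all stereocentres are inverted: mirror images); a stereocentre at a saturated ring carbon is drawn R in compound 2 and S in compound 3; a stereocentre at a saturated ring carbon is drawn R in compound 2 and S in compound 3; a stereocentre at a saturated ring carbon is drawn S in compound 2 and R in compound 3; a stereocentre at a sulfur is drawn R in compound 2 and S in compound 3. Among the compounds with values here, the one measured step that bears on a change of configuration is a step that the two limits leave unreadable from compound 1 to compound 2, and its size is unknown, so in this assay no direction and no size beyond the scatter can be expected from the evidence. The step that the limit leaves unreadable from compound 2 to compound 3 is accordingly an estimate resting only on the two limits. Compound 3 is expected to give 20000 nM, with a range from 2000 nM to 100000 nM.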

Compound 3, inhibition constant: < 100000 nM
Compound 3: only a limit was reported; the forecaster's own chance of this, stated with the estimate: 50%; the middle value does not contradict the limit.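

Compound 3 gives < 100000 nM in this assay and this is again a limit and not a number. Going by these compounds alone, no step among compound 1, compound 2 and compound 3 can be read, since all three rest on one shared limit: the limit of < 100000 nM in this assay, at which 3 of the 3 values shown sit. The compounds shown leave open whether a change of configuration as drawn alters the binding affinity at all, and by how much.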